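Dropping a Phosphate from a Propyl Uracil Nucleotide

The compounds below may be only part of what the source reports. "The series", "measured", "known", "first", "only" and "open" are said of these compounds alone.

Compound 1 `O=c1[nH]c(=O)n([C@@H]2O[C@H](COP(=O)(O)OP(=O)(O)OP(=O)(O)O)[C@@H](O)[C@H]2O)cc1Br` is the bromine-bearing member of this set. In an in vitro functional assay on 1321-N1 cells for agonist activity at P2Y purinoceptor 4 (Homo sapiens) (a lower number here means that less compound is needed, a higher number that more compound is needed for the effect), compound 1 gives 3460 nM. Compound 2 `Cc1cc(=O)n([C@@H]2O[C@H](COP(=O)(O)OP(=O)(O)OP(=O)(O)O)[C@@H](O)[C@H]2O)c(=O)[nH]1` carries a methyl group where compound 1 has bromine. In this assay compound 2 reaches only the limit of the assay, > 100000 nM. That change is an at least 28-fold higher number from compound 1 to compound 2 (1.46 log units; beyond the scatter). Compound 3 `CCCc1cc(=O)n([C@@H]2O[C@H](COP(=O)(O)OP(=O)(O)OP(=O)(O)O)[C@@H](O)[C@H]2O)c(=O)[nH]1` carries a propyl chain in place of the methyl. In this assay compound 3 also stops at the limit, > 100000 nM. The step that the two limits leave unreadable from compound 2 to compound 3 is unreadable since both values are limits. Compound 3 therefore stands at the limit of > 100000 nM in this assay, at which 2 of the 3 values shown sit, with no number of its own. Compound 4 `CCCc1cc(=O)n([C@@H]2O[C@H](COP(=O)(O)OP(=O)(O)O)[C@@H](O)[C@H]2O)c(=O)[nH]1` differs from compound 3 in the phosphate chain: a hydrogen atom in place of a group of 4 heavy atoms (3 oxygen, 1 phosphorus; no ring), on an oxygen. Within the data shown here, no measured step touches the phosphate chain, so none bears directly on this change. Because compound 3 gives only a limit > 100000 nM, no measured step can be read downward from it. Compound 4 is expected to remain at the limit, a step that the limit leaves unreadable from compound 3 to compound 4. Compound 4 is thus estimated at 150000 nM, between 50000 nM and 500000 nM.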

Compound 4, half-maximal effective concentration: > 100000 nM
Compound 4 gave a limit, no number; the forecaster's own chance of this, stated with the estimate: 85%; the middle value is on the limit's open side.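

Compound 3 and compound 4 both stop at a limit of the assay rather than a number, so no step can be read between them: the limit of > 100000 nM in this assay, at which 3 of the 4 values shown sit.

The compounds shown leave open whether a hydrogen in place of that terminal phosphorus-bearing group changes the concentration needed in this assay, and by how much.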